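Amino for methoxy on the side chain of compound 3

The source may report more compounds than this note shows. Statements on the series, on what has been measured and on what is new or still open speak of the compounds shown alone.

Measured in a functional assay on CAL-33 cells (Homo sapiens) for inhibition; a higher number here means a weaker inhibitor of growth, a lower number a stronger inhibitor of growth:
compound 1 `CC(C)CC1Sc2nnc(-c3[nH]nc4c3CCC4)n2N=C1c1ccc(Cl)c(Cl)c1` gives 3500 nM
compound 2 `COc1ccc(C2=Nn3c(nnc3-c3cc(-c4ccc(F)cc4)n[nH]3)SC2C)cc1` gives 29500 nM
compound 3 `COCCC1Sc2nnc(-c3cc(-c4ccccc4)n[nH]3)n2N=C1c1ccc(OC)cc1` gives 40 nM

Compound 3 has the lowest number of the three; its nearest neighbour is compound 1, and compound 2 stands furthest away, both gaps lying beyond the scatter. Compound 4 `COc1ccc(C2=Nn3c(nnc3-c3cc(-c4ccccc4)n[nH]3)SC2CCN)cc1` differs from compound 3 in one place: amino in place of methoxy on a saturated chain carbon, two bonds along the chain from a saturated ring carbon. For the measured compounds named here, no measured pair shows this change, so its size cannot be read from the series. The expected step in this assay from compound 3 to compound 4 is a 2.0-fold higher number from compound 3 to compound 4 (0.30 log units; within the scatter), a modest rise that might still fall inside the scatter. Compound 4 is therefore estimated at 80 nM, with a range from 15 nM to 500 nM.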

Compound 4, concentration for 50% growth inhibition: 2500 nM
Estimate against measurement, compound 4: 31-fold (1.49 log units) below; measured number above the stated range.
By their numbers in this assay, from the lowest: compound 3; then compounds 4 and 1 (each within the scatter of the next); then compound 2.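

The change from 2-methoxyethyl to 2-aminoethyl brings a 63-fold higher number from compound 3 to compound 4 (1.80 log units; beyond the scatter) in this assay and gives the series its first reading at a single position. Compound 1 and compound 2 differ from compound 3 in several places, so they could not show that the end of this side chain matters so strongly. With the rest of the structure unchanged, the position is clearly sensitive to this exchange. Nothing available explains the loss.

Going by these compounds, whether it is specific to amino remains open. A hydroxyl, a dimethylamino group or a longer chain carrying the amino group would help separate these possibilities.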